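This account rests on a few compounds, and the source may have more. Where it says the series, first, only, none or still open, it means among the compounds named here.

Of the compounds shown here, three have so far been measured in a physicochemical assay for pharmacokinetics, read by spectrophotometry, in phosphate buffer, with a stated time of 5 min, tested at 40 uM, in the presence of a further agent that is not named here; on this read-out higher numbers stand for a longer-lived compound and lower numbers for a shorter-lived compound. Compound 1 `CC1=C(CC(=O)Oc2ccc(C(N)=S)cc2)c2cc(F)ccc2/C1=C\c1ccc([S+](C)[O-])cc1` gives 0.0517 h. Compound 2 `CC(C)Cc1ccc(C(C)C(=O)Oc2ccc(-c3cc(=S)ss3)cc2)cc1` gives 0.0233 h, and compound 3 `COc1ccc2c(c1)c(CC(=O)Oc1ccc(-c3cc(=S)ss3)cc1)c(C)n2C(=O)c1ccc(Cl)cc1` gives 0.03 h. Compound 2 and compound 3 lie within the usual scatter of one another, so no order between them can be read. Compound 1 stands higher than compound 2 by more than the scatter, so compound 1 counts as the longer-lived of those two. The untested compound 4 `CC(C(=O)Oc1ccc(-c2cc(=S)ss2)cc1)c1ccc(C(=O)c2ccccc2)cc1` differs from compound 2 in a single place: benzoyl in place of isobutyl on an aromatic carbon. Within the data shown here, all three measured compounds remain short-lived although the part in which they differ varies widely, and no measured pair isolates this particular change, so there is nothing to point one way or the other. The step of a 1.1-fold higher number from compound 2 to compound 4 (0.03 log units; within the scatter) is therefore expected to be small, in no direction beyond the scatter. Compound 4 is expected to give 0.025 h in this assay, with a range from 0.012 h to 0.05 h.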

Compound 4, half-life: 0.0567 h
The estimate for compound 4 lay 2.3-fold (0.36 log units) below the measured number; measured number above the stated range.
By their numbers in this assay, from the lowest: compounds 2, 3, 1 and 4 (each within the scatter of the next, the first and the last beyond it).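

Putting benzoyl in place of isobutyl, on an aromatic carbon para to a large group, gives a 2.4-fold higher number from compound 2 to compound 4 (0.39 log units; beyond the scatter) in this assay and so moves the half-life by a modest step. This is the only pair shown that differs in one place, and it gives the first sign that the group at this position can shift the number, even though the earlier compounds gave no direction for it. No measurement shown here accounts for the step.

The compounds shown leave open whether the ring or the carbonyl of benzoyl carries the step, and a plain phenyl or a longer chain at this place could separate the two. Going by these compounds, how an amine or a carboxylic acid at the same place would read in this assay also remains open.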